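Adding a Fluorine to the Pendant Phenyl of Compound 3

The compounds below may be only part of what the source reports. "The series", "measured", "known", "first", "only" and "open" are said of these compounds alone.

Compound 1 `Fc1ccc(-c2cc(-c3ccc4cc(F)ccc4n3)n(-c3ccccc3)n2)cc1`: 87.5%
Compound 2 `Fc1ccc(-c2cc(-c3ccc4cc(F)ccc4n3)n(-c3ccc(F)cc3)n2)cc1`: 86.5%
Compound 3 `COc1ccc(-n2nc(-c3ccccc3)cc2-c2ccc3cc(F)ccc3n2)cc1`: 97.4%

In an ADME assay on Huh-7 cells (Homo sapiens) for cytotoxicity, read by XTT assay, with a stated time of 3 days, tested at 200 uM (a higher number here means a weaker effect of the compound at the concentration tested, a lower number a stronger effect), compound 3 stands at the top of the three numbers; its gap to compound 1 is within the usual scatter, while its gap to compound 2 lies beyond it. Compound 4 `COc1ccc(-n2nc(-c3ccc(F)cc3)cc2-c2ccc3cc(F)ccc3n2)cc1` differs from compound 3 by one change: fluoro in place of hydrogen on an aromatic carbon. The same change has been measured once before, on the same ring, between compound 1 and compound 2, where it gave a number 1 percentage points lower from compound 1 to compound 2 (within the scatter). On that evidence no step beyond the scatter is expected in this assay from compound 3 to compound 4, and the expected step is a number 2.4 percentage points lower from compound 3 to compound 4 (within the scatter). Compound 4 is therefore estimated at 95%, with a range from 85% to 100%.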

Compound 4, a percentage reported as activity, at one concentration (the size of the read-out at that concentration, not a potency): 52.6%
Compound 4: the middle estimate sits 42.4 percentage points above what was measured; the measured number lies below the stated range.
By their numbers in this assay, from the lowest: compound 4; then compounds 2, 1 and 3 (each within the scatter of the next, the first and the last beyond it).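

The change from phenyl to 4-fluorophenyl has no fixed size in this assay, and its effect depends on the core that carries it: the same change on two cores in this assay, a number 1 percentage points lower (within the scatter) from compound 1 to compound 2 and a number 44.8 percentage points lower (beyond the scatter) from compound 3 to compound 4, 43.8 percentage points apart, beyond the scatter of two such steps

With the methoxy group present, fluoro gives a number 44.8 percentage points lower from compound 3 to compound 4 (beyond the scatter), while with the 4-fluorophenyl present, methoxy in place of fluoro gives a number 33.9 percentage points lower from compound 2 to compound 4 (beyond the scatter) and methoxy in place of hydrogen gives a number 34.9 percentage points lower from compound 1 to compound 4 (beyond the scatter). Only compound 4 carries both groups, and only compound 4 shows this stronger effect at the concentration tested.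

The compounds shown leave open whether chloro in place of the fluoro, or an amine in place of the methoxy, would give a similar drop. They also cannot tell why the two groups act together.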